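The source may report more compounds than this note shows. Statements on the series, on what has been measured and on what is new or still open speak of the compounds shown alone.

Measured in a functional assay on DU-145 cells (Homo sapiens) for inhibition, read by MTT assay, with stated times of 18 h and 4 h; on this read-out lower numbers stand for stronger inhibition and higher numbers for weaker inhibition:
- compound 1 `CCCCCCCCCCOP(=O)(O)OCCSC(=S)N1CCN(C)CC1`: 82300 nM
- compound 2 `CCCCCCOP(=O)(O)OCCSC(=S)N1CCN(C)CC1`: > 100000 nM (a limit of the assay, not a number)

Compound 2 stands at the limit of > 100000 nM in this assay, at which 1 of the 2 values shown sits. Compound 3 `CCCOP(=O)(O)OCCSC(=S)N1CCN(C)CC1` differs from compound 2 by hydrogen in place of propyl on a saturated chain carbon, three bonds along the chain from an oxygen on an unsaturated carbon, or hexyl to propyl. Among the compounds with values here, one measured step bears on this, the similar chain change an at least 1.2-fold higher number from compound 1 to compound 2 (0.08 log units; that floor lies within the scatter). On that step alone, a modest move towards weaker inhibition is expected in this assay, estimated as a step that the limit leaves unreadable from compound 2 to compound 3. The expected value for compound 3 is 140000 nM, with an estimated range of 90000 nM to 300000 nM.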

Compound 3, half-maximal inhibitory concentration: > 100000 nM
Compound 3 ended at the assay's limit (the forecaster's own chance of this, stated with the estimate: 85%); the middle value is on the limit's open side.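

In this assay compound 3 gives > 100000 nM, a limit of the assay and not a number. Going from hexyl to propyl gives a step that cannot be read, so the shorter chain adds a second compound at the same ceiling: the limit of > 100000 nM in this assay, at which 2 of the 3 values shown sit.

Within the data shown here, the one readable step is an at least 1.2-fold higher number from compound 1 to compound 3 (0.08 log units; that floor lies within the scatter).

Still open, going by these compounds, is whether a longer chain than that of compound 1 would give a number clear of the limit and beyond the scatter. Also open, on these data alone, is how an amine or a carboxylic acid at the chain end would read.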